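Chlorophenyl swap in the series: a working estimate

The compounds below may be only part of what the source reports. "The series", "measured", "known", "first", "only" and "open" are said of these compounds alone.

In a functional assay on MIA PaCa-2 cells (Homo sapiens) for inhibition, read by MTT assay, with a stated time of 48 h (on this read-out higher numbers stand for weaker inhibition of growth and lower numbers for stronger inhibition of growth), compound 1 `CN1CC[C@H](c2c(O)cc(O)c3c(=O)cc(/C=C/c4ccccc4)oc23)[C@H](O)C1` gives 2000 nM, compound 2 `CN1CC[C@H](c2c(O)cc(O)c3c(=O)cc(/C=C/c4cccc(Cl)c4)oc23)[C@H](O)C1` gives 10000 nM and compound 3 `CN1CC[C@H](c2c(O)cc(O)c3c(=O)cc(/C=C/c4c(F)c(F)c(F)c(F)c4F)oc23)[C@H](O)C1` gives 1000 nM. Compound 2 therefore carries the highest of the three numbers, and its steps to both others lie beyond the scatter.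

Compound 4 `CN1CC[C@H](c2c(O)cc(O)c3c(=O)cc(/C=C/c4ccccc4Cl)oc23)[C@H](O)C1` keeps the shared core and differs only in the aryl group: 2-chlorophenyl in place of 3-chlorophenyl on a double-bonded chain carbon bound to a double-bonded chain carbon. Here 2-chlorophenyl stands in place of 3-chlorophenyl on a double-bonded chain carbon bound to a double-bonded chain carbon.

Going by the values given here, no measured step moves the chlorine itself, so the evidence is indirect. Adding chloro gave a 5.0-fold higher number from compound 1 to compound 2 (0.70 log units; beyond the scatter), a modest step. Exchanging phenyl for 2,3,4,5,6-pentafluorophenyl gave a 2.0-fold lower number from compound 1 to compound 3 (0.30 log units; within the scatter), and exchanging 3-chlorophenyl for that group gave a 10-fold lower number from compound 2 to compound 3 (1.00 log units; beyond the scatter). The data do not show whether the penalty seen with 3-chlorophenyl carries over to 2-chlorophenyl, so a partial return towards the other two values is expected. The estimated step is a 2.5-fold lower number from compound 2 to compound 4 (0.40 log units; beyond the scatter), and it remains uncertain. For compound 4 the expected value is 4000 nM, with an estimated range of 1200 nM to 13000 nM.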

Compound 4, concentration for 50% growth inhibition: 8000 nM
The estimate for compound 4 lay 2.0-fold (0.30 log units) below the measured number; the range from low to high includes it.
By their numbers in this assay, from the lowest: compounds 3 and 1 (each within the scatter of the next); then compounds 4 and 2 (each within the scatter of the next).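

In this assay 2-chlorophenyl in place of 3-chlorophenyl gives a 1.3-fold lower number from compound 2 to compound 4 (0.10 log units; within the scatter) and so leaves the two chlorophenyl isomers unresolved at this place on the double-bonded chain carbon. Chloro in place of hydrogen on an aromatic carbon gives a 4.0-fold higher number from compound 1 to compound 4 (0.60 log units; beyond the scatter) and shows that the penalty first seen with compound 2 is not confined to 3-chlorophenyl. 2-Chlorophenyl in place of 2,3,4,5,6-pentafluorophenyl gives an 8.0-fold higher number from compound 3 to compound 4 (0.90 log units; beyond the scatter) and compound 3 goes against any reading that halogen on this aryl group alone raises the number.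

No supporting evidence bears on the source of this chloro penalty. On these data alone, whether an amine or a carboxylic acid in place of the chloro would read with compound 2 and compound 4 or with compound 3 remains open.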